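A few compounds are considered here, and "the series" means these few. Any claim that something is new, unique, unknown or untested is made for them only; others in the source may bear on it.

Measured in a functional assay on MDA-MB-468 cells (Homo sapiens) for inhibition, read by sulforhodamine B assay, with a stated time of 48 h; a lower number here means a stronger inhibitor of growth, a higher number a weaker inhibitor of growth:
Compound 1 `O=C(Nc1cccc(-n2cc(-c3ccncc3)c(-c3ccc(Cl)c(O)c3)n2)c1)Nc1cccc(C(F)(F)F)c1`: 7830 nM
Compound 2 `COc1cc(-c2nn(-c3cccc(NC(=O)c4cccc(C(F)(F)F)c4)c3)cc2-c2ccncc2)ccc1Cl`: 4560 nM

Compound 2, at 4560 nM, stands within the usual scatter of compound 1, so the two numbers cannot be told apart. Compound 3 `COc1cc(-c2nn(-c3cccc(NC(=O)Nc4cccc(C(F)(F)F)c4)c3)cc2-c2ccncc2)ccc1Cl` differs from compound 2 in one place, with (3-(trifluoromethyl)phenyl)amino in place of 3-(trifluoromethyl)phenyl on a carbonyl carbon. Among the compounds with values here, no measured pair shows this change alone. Compound 1 carries the same entering group, though it also differs elsewhere, and gives 7830 nM, so no change beyond the scatter is expected. The expected result is a 1.0-fold lower number from compound 2 to compound 3 (0.01 log units; within the scatter). Compound 3 is estimated at 4500 nM, with an expected range of 1600 nM to 12000 nM.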

Compound 3, concentration for total growth inhibition: 2160 nM
Compound 3: middle estimate off by 2.1-fold (0.32 log units), on the high side, within the range that was stated.
By their numbers in this assay, from the lowest: compound 3; then compounds 2 and 1 (each within the scatter of the next).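

In this assay (3-(trifluoromethyl)phenyl)amino in place of 3-(trifluoromethyl)phenyl on the carbonyl carbon gives a 2.1-fold lower number from compound 2 to compound 3 (0.32 log units; beyond the scatter) as a modest step that could be read alone. With that group kept, methyl in place of hydrogen on the oxygen on the aromatic ring gives a 3.6-fold lower number from compound 1 to compound 3 (0.56 log units; beyond the scatter) as a second modest step, so both places respond in these compounds. Nothing available explains either step.

The compounds shown leave open whether an ethyl group on that oxygen would lower the number further. They also leave open what a nitrile in place of trifluoromethyl would do.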